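This account rests on a few compounds, and the source may have more. Where it says the series, first, only, none or still open, it means among the compounds named here.

Measured so far:
Compound 1 `Nc1cc(N)c2nc(-c3ccccc3)c(NCc3ccc(F)cc3)nc2c1` in a functional assay on K562 cells (Homo sapiens) for inhibition, read by sulforhodamine B assay, with a stated time of 48 h (on this read-out lower numbers stand for stronger inhibition of growth and higher numbers for weaker inhibition of growth), gives < 100000 nM, which is a limit of the assay.
Compound 2 `COc1ccc(Sc2nc3cc(N)cc(N)c3nc2-c2ccccc2)cc1` in this assay gives < 100000 nM, likewise a limit.

Compound 2 thus stands at a limit, as the limit of < 100000 nM in this assay, at which 2 of the 2 values shown sit, records, and no number places it. The step that the two limits leave unreadable from compound 1 to compound 2 is unreadable for the same reason. Compound 3 `Nc1cc(N)c2nc(-c3ccccc3)c(Sc3ccc(Cl)c(Cl)c3)nc2c1` differs from compound 2 by 3,4-dichlorophenyl in place of 4-methoxyphenyl on a sulfur. For the measured compounds named here, no measured step bears on this change, so no direction in this assay can be read. Compound 3 is therefore estimated at 5000 nM, between 500 nM and 50000 nM. That expectation amounts to a step that the limit leaves unreadable from compound 2 to compound 3.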

Compound 3, concentration for total growth inhibition: < 100000 nM
Compound 3 gave a limit, no number; the forecaster's own chance of this, stated with the estimate: 30%; the middle value lies beyond the limit too.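

Compound 3 also gives only a limit, so no step from compound 1 or compound 2 to compound 3 can be read: the limit of < 100000 nM in this assay, at which 3 of the 3 values shown sit.

The compounds shown leave open how the (4-fluorobenzyl)amino, (4-methoxyphenyl)sulfanyl and (3,4-dichlorophenyl)sulfanyl groups compare in this assay.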